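Hydroxymethyl on Two Different Rings of One Series

The source may hold more compounds than are shown below. What is called first, only, known or untested is meant among the compounds shown, and "the series" means these compounds.

Three compounds sharing one core were measured in a functional assay (aorta) with Oryctolagus cuniculus as the target; on this read-out higher numbers stand for weaker inhibition and lower numbers for stronger inhibition. Compound 2 `Cc1coc(-c2nn(Cc3ccccc3F)c3ncccc23)n1` gives 1200 nM. Compound 1 `Cc1nc(-c2nn(Cc3ccccc3F)c3ncccc23)oc1CO` differs from it by hydroxymethyl in place of hydrogen on an aromatic carbon and gives 900 nM, a step of a 1.3-fold lower number from compound 2 to compound 1 (0.12 log units; within the scatter). Compound 3 `Fc1ccccc1Cn1nc(-c2ncccn2)c2cccnc21` differs from compound 2 by pyrimidin-2-yl in place of 4-methyl-1,3-oxazol-2-yl on an aromatic carbon; in this assay compound 3 gives 1250 nM. That step is a 1.0-fold higher number from compound 2 to compound 3 (0.02 log units; within the scatter), and the step of a 1.4-fold higher number from compound 1 to compound 3 (0.14 log units; within the scatter) is likewise small. Compound 4 `OCc1ccnc(-c2nn(Cc3ccccc3F)c3ncccc23)n1` has not been measured; it differs from compound 3 by hydroxymethyl in place of hydrogen on an aromatic carbon. Going by the values given here, this is the same kind of change as the one from compound 2 to compound 1, not the same: there the place was on a five-membered aromatic ring with 1 nitrogen and 1 oxygen, next to the ring oxygen, next to the ring atom that bears a methyl group, whereas here it is on a six-membered aromatic ring with 2 nitrogen, next to the ring nitrogen, meta to a large group. The step expected for compound 4 in this assay is a 1.3-fold lower number from compound 3 to compound 4 (0.10 log units; within the scatter). That expectation rests on the step of a 1.3-fold lower number from compound 2 to compound 1 (0.12 log units; within the scatter) lying within the scatter and on compound 3 giving 1250 nM. Compound 4 is therefore estimated at 1000 nM, between 400 nM and 2500 nM.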

Compound 4, half-maximal inhibitory concentration: 1300 nM
Compound 4: the middle estimate sits 1.3-fold (0.11 log units) below what was measured; measured number inside the range.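

In this assay, hydroxymethyl added to the pyrimidin-2-yl group gives a step of a 1.0-fold higher number from compound 3 to compound 4 (0.02 log units; within the scatter), and the comparison with the earlier step reads: the same change on two cores in this assay, a 1.3-fold lower number (0.12 log units; within the scatter) from compound 2 to compound 1 and a 1.0-fold higher number (0.02 log units; within the scatter) from compound 3 to compound 4, 1.4-fold (0.14 log units) apart, within the scatter of two such steps Exchanging the whole group attached to the shared core also stays within the scatter, with steps of a 1.1-fold higher number from compound 2 to compound 4 (0.03 log units; within the scatter) and a 1.4-fold higher number from compound 1 to compound 4 (0.16 log units; within the scatter). This shows that the hydroxymethyl change behaves alike on these two cores as far as this read-out can tell, but it does not show a real effect being carried from one core to the other, since neither step rises above the scatter, and two cores cannot establish a rule for the series.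

From the compounds shown here alone, whether an amine or a carboxylic acid in place of hydroxymethyl would give a step beyond the scatter remains open. So does the outcome for a longer chain, or for hydroxymethyl at another place on the ring.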